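The compounds below may be only part of what the source reports. "The series", "measured", "known", "first", "only" and "open" are said of these compounds alone.

Measured compounds:
compound 1 `CC(C)c1c(C(=O)N(C)Cc2cccc(F)c2)nn(-c2ccc(F)cc2)c1CC[C@@H](O)C[C@@H](O)CC(=O)O` – 4.1 nM
compound 2 `CC(C)c1c(C(=O)N2CCCC2c2ccccc2)nn(-c2ccc(F)cc2)c1OC[C@@H](O)C[C@@H](O)CC(=O)O` – 14 nM
compound 3 `CC(C)c1c(C(=O)NCc2cccc(Cl)c2)nn(-c2ccc(F)cc2)c1OC[C@@H](O)C[C@@H](O)CC(=O)O` – 5.4 nM

In an assay on microsomes from liver for inhibition of 3-hydroxy-3-methylglutaryl-coenzyme A reductase (Rattus norvegicus) (on this read-out lower numbers stand for stronger inhibition and higher numbers for weaker inhibition), compound 3 gives 5.4 nM, the second highest of the three numbers. Compound 1 gives 4.1 nM, which lies within the scatter of compound 3, while compound 2 gives 14 nM, a higher number beyond the scatter. Going by the values given here, the only step among the measured compounds is a 2.6-fold lower number from compound 2 to compound 3 (0.41 log units; beyond the scatter), so an exchange of the group on the carbonyl carbon has moved the number modestly in this set.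

Compound 4 `CC(C)c1c(C(=O)N(C)Cc2cccc(F)c2)nn(-c2ccc(F)cc2)c1OC[C@@H](O)C[C@@H](O)CC(=O)O` is not yet measured. It differs from compound 3 by (3-fluorobenzyl)(methyl)amino in place of (3-chlorobenzyl)amino on a carbonyl carbon. Compound 1 carries the same (3-fluorobenzyl)(methyl)carbamoyl group on a different linker to the dihydroxy acid chain, and its value sits within the scatter of compound 3. The step from compound 2 to compound 3 shows that amide changes at this position can shift the number, but nothing here points to a shift beyond the scatter for this change. Compound 4 is therefore expected to give 6 nM (range 2.5 nM to 15 nM), which means an expected step of a 1.1-fold higher number from compound 3 to compound 4 (0.05 log units; within the scatter).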

Compound 4, half-maximal inhibitory concentration: 14 nM
Compound 4: the middle estimate sits 2.3-fold (0.37 log units) below what was measured, and the stated range covers the measured number.
By their numbers in this assay, from the lowest: compounds 1 and 3 (each within the scatter of the next); then compounds 2 and 4 (each within the scatter of the next).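

In this assay, the amide on the carbonyl carbon responded to this exchange beyond the scatter (a 2.6-fold higher number from compound 3 to compound 4 (0.41 log units; beyond the scatter)), whereas compound 4 matched the 2-phenylpyrrolidin-1-yl amide (no change at the digits printed from compound 2 to compound 4 (within the scatter)). With the (3-fluorobenzyl)(methyl)carbamoyl group held constant, the linker on the aromatic carbon also mattered: (5-carboxy-2,4-dihydroxypentyl)oxy in place of 6-carboxy-3,5-dihydroxyhexyl gave a 3.4-fold higher number from compound 1 to compound 4 (0.53 log units; beyond the scatter) and so the value of compound 1 did not carry over to the oxygen-linked chain. No measurement shown accounts for either step.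

The exchange replaced chlorine with fluorine and the amide hydrogen with methyl together, so the compounds shown do not separate these two changes. A (3-fluorobenzyl)amino or (3-chlorobenzyl)(methyl)amino group on the same carbonyl carbon would tell them apart.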